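From Methylsulfonyl to Ethylsulfamoyl on a Shared Core

The source may hold more compounds than are shown below. What is called first, only, known or untested is meant among the compounds shown, and "the series" means these compounds.

Compound 2 `CCCS(=O)(=O)Nc1ccc(F)c(C(=O)c2n[nH]c3ncc(-c4ccc(S(C)(=O)=O)cc4)cc23)c1F` was tested in an assay for binding affinity to dual specificity mitogen-activated protein kinase kinase 4 (Homo sapiens), read by KINOMEscan, tested at 100 nM (a higher number here means a weaker effect of the compound at the concentration tested, a lower number a stronger effect), and gave 1.5%. Its only companion so far, compound 1 `CCCS(=O)(=O)Nc1ccc(F)c(C(=O)c2n[nH]c3ncc(-c4ccc(F)cc4)cc23)c1F`, gives 2.1% in this assay; the two sit within the scatter of each other, as a number 0.6 percentage points lower from compound 1 to compound 2 (within the scatter) shows. Compound 2 therefore stands at one of two numbers that cannot be told apart. The next compound, compound 3 `CCCS(=O)(=O)Nc1ccc(F)c(C(=O)c2n[nH]c3ncc(-c4ccc(S(=O)(=O)NCC)cc4)cc23)c1F`, is not yet measured. It differs from compound 2 in one place: ethylamino in place of methyl on a sulfonyl sulfur. Among the compounds with values here, no measured step touches this kind of change; the one step that exists, a number 0.6 percentage points lower from compound 1 to compound 2 (within the scatter), concerns a different exchange and stayed within the scatter. With nothing pointing another way, the step of a number 0.5 percentage points higher from compound 2 to compound 3 (within the scatter) is expected to remain within the scatter as well. For compound 3 the estimated value in this assay is 2%, with a range from 0.4% to 9%.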

Compound 3, a percentage reported as activity, at one concentration (the size of the read-out at that concentration, not a potency): 3%
Compound 3: the middle estimate sits 1 percentage points below what was measured, within the range that was stated.
By their numbers in this assay, from the lowest: compounds 2, 1 and 3 (each within the scatter of the next).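

In this assay the exchange of methyl for ethylamino on a sulfonyl sulfur, which brings in a nitrogen and 1 hydrogen-bond donor, gives a number 1.5 percentage points higher from compound 2 to compound 3 (within the scatter) and so cannot be told apart from no change. The comparison with the fluoro compound reads the same way, with a number 0.9 percentage points higher from compound 1 to compound 3 (within the scatter) on record, so fluoro, methylsulfonyl and ethylsulfamoyl on this aromatic carbon all give numbers that stay together at the one concentration tested. Nothing on hand says why these numbers stay together.

From the compounds shown here alone, whether a carboxylic acid or an amine in this place, or a longer chain such as butyl on the sulfamoyl nitrogen, would move the number beyond the scatter remains open. A read-out at one concentration is also not a potency, so any real differences among these three compounds remain hidden.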